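The source may report more compounds than this note shows. Statements on the series, on what has been measured and on what is new or still open speak of the compounds shown alone.

Measured compounds:
compound 1 `CS(=O)(=O)c1cc(N)c2ncccc2c1[N+](=O)[O-]` – in an assay for binding affinity to Neuropeptide Y receptor type 1 (Homo sapiens), read by radioligand binding (a higher number here means a weaker inhibitor, a lower number a stronger inhibitor), gives > 10000 nM, a limit of the assay, not a number.
compound 2 `Nc1cc(S(=O)(=O)c2ccccc2Br)c([N+](=O)[O-])c2cccnc12` – in this assay gives 234 nM.

Compound 2 holds the only number shown in this assay; the other value is a limit. Within the data shown here, the single measured step, an at least 42-fold lower number from compound 1 to compound 2 (1.63 log units; beyond the scatter), rests on (the limit of > 10000 nM in this assay, at which 1 of the 2 values shown sits), so its size is a lower bound only. Compound 3 `Nc1cc(S(=O)(=O)c2ccccc2F)c([N+](=O)[O-])c2cccnc12` differs from compound 2 by fluoro in place of bromo on an aromatic carbon. Among the measured compounds shown here, no measured step exchanges one halogen for another; the one step available swaps a methyl for a 2-bromophenyl on the sulfonyl sulfur and shows that the aryl sulfone is where the affinity sits, but it says nothing about the ring substituent itself. The step expected in this assay is therefore small, a 1.7-fold higher number from compound 2 to compound 3 (0.23 log units; within the scatter), if anything toward a weaker inhibitor, and within or near the scatter. Compound 3 is estimated at 400 nM, with a range from 120 nM to 1500 nM.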

Compound 3, inhibition constant: 58 nM
Compound 3: middle estimate off by 6.9-fold (0.84 log units), on the high side; measured number outside the range, below it.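

The halogen on this ring is not a silent position in this assay: a 4.0-fold lower number from compound 2 to compound 3 (0.61 log units; beyond the scatter), a change beyond the scatter that the methyl-to-aryl step could not reveal. Affinity therefore depends on the ring substituent as well as on the aryl sulfone itself, and with these two compounds fluoro is the better of the two halogens at this place. Compound 1 stands at a limit of the assay, so the step of an at least 170-fold lower number from compound 1 to compound 3 (2.23 log units; beyond the scatter) is a lower bound only: the limit of > 10000 nM in this assay, at which 1 of the 3 values shown sits.

From the compounds shown here alone, whether chloro or methoxy at the same place would match fluoro or fall nearer bromo remains open, as does whether an unsubstituted phenyl would do better or worse than either halogen. Also open, going by these compounds, is how fluoro would behave elsewhere on the same ring.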